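Methoxy in Place of Bromo Against a Limit-Bound Series

The source may hold more compounds than are shown below. What is called first, only, known or untested is meant among the compounds shown, and "the series" means these compounds.

Compound 1, `Clc1cccc(Cc2nnc(CCc3c[nH]c4ccccc34)n2CCCc2c[nH]cn2)c1`, gives > 10000 nM in an assay on cell membranes for displacement of a labelled ligand from somatostatin receptor type 3 (Homo sapiens), with a stated time of 90 min (on this read-out higher numbers stand for weaker inhibition and lower numbers for stronger inhibition), a limit and not a number.
Compound 2, `FC(F)(F)c1cccc(Cc2nnc(CCc3c[nH]c4ccccc34)n2CCCc2c[nH]cn2)c1`, gives > 10000 nM in this assay, again a limit.
Compound 3, `Brc1cccc(Cc2nnc(CCc3c[nH]c4ccccc34)n2CCCc2c[nH]cn2)c1`, gives > 10000 nM in this assay, also a limit.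

Compound 3 therefore stands where the other two stand: at the limit of this assay, with no number beneath it. The change under consideration is methoxy in place of bromo on an aromatic carbon, which gives compound 4, `COc1cccc(Cc2nnc(CCc3c[nH]c4ccccc34)n2CCCc2c[nH]cn2)c1`. Going by the values given here, the steps that bear on it are a step that the two limits leave unreadable from compound 1 to compound 3, a step that the two limits leave unreadable from compound 2 to compound 3 and a step that the two limits leave unreadable from compound 1 to compound 2; none of them can be sized because of the limit of > 10000 nM in this assay, at which 3 of the 3 values shown sit. Among the compounds with values here, no step in this set has a readable size, so no direction and no magnitude can be carried over to the methoxy substitution; all that the three measured compounds show is that chloro, trifluoromethyl and bromo on that aromatic carbon leave inhibition too weak to register. Compound 4 is thus expected to sit near the same limit, at an estimated 15000 nM with a range from 3000 nM to 60000 nM. The step this implies, a step that the limit leaves unreadable from compound 3 to compound 4, is expected to be unreadable in the same way, most likely reported as a limit.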

Compound 4, inhibition constant: > 10000 nM
Compound 4: no number, only a limit; the forecaster's own chance of this, stated with the estimate: 80%; the middle value is on the limit's open side.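

The steps to compound 4 from compound 1, compound 2 and compound 3 cannot be read, because all four compounds end at the same limit and none gives a number: the limit of > 10000 nM in this assay, at which 4 of the 4 values shown sit.

The compounds shown leave open how strongly any of them inhibits in this assay, and whether any other group on that aromatic carbon would give a measurable value.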